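A few compounds are considered here, and "the series" means these few. Any claim that something is new, unique, unknown or untested is made for them only; others in the source may bear on it.

Measured so far:
- compound 1, `CCc1ccc(-n2nc(-c3ccc(C(F)(F)F)cc3O)nc2-c2ccccc2O)cc1`: 64.4%
- compound 2, `Oc1cc(C(F)(F)F)ccc1-c1nc(-c2ccccc2O)n(-c2ccc(C(F)(F)F)cc2)n1`: 70.7%

In a functional assay on PC-12 cells (Rattus norvegicus) for cytotoxicity, read by MTT assay, with stated times of 2 h and 24 h, tested at 1 uM (on this read-out lower numbers stand for a weaker effect and higher numbers for a stronger effect at the one concentration tested), compound 1 gives 64.4% and compound 2 gives 70.7%. Among the compounds with values here, the one measured step, a number 6.3 percentage points higher from compound 1 to compound 2 (within the scatter), is within the scatter, so the two values cannot be ordered; compound 2 simply shows the higher of the two numbers, with compound 1 as its only neighbour.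

Compound 3, `Oc1cc(C(F)(F)F)ccc1-c1nc(-c2ccccc2O)n(-c2cccc(C(F)(F)F)c2)n1`, is not yet measured. It differs from compound 2 as follows: 3-(trifluoromethyl)phenyl in place of 4-(trifluoromethyl)phenyl on an aromatic nitrogen.

Within the data shown here, no measured step bears directly on this change. Among the measured compounds shown here, the only step available, a number 6.3 percentage points higher from compound 1 to compound 2 (within the scatter), concerns exchanging one group for another on the same aromatic carbon of the same phenyl ring, whereas the change from compound 2 to compound 3 keeps the atoms and moves the trifluoromethyl group to another carbon of that ring. That step was within the scatter and gives no ground to expect a movement beyond the scatter here either.

For compound 3 the estimate in this assay is 68%, with a range from 52% to 84%. The expected step is a number 2.7 percentage points lower from compound 2 to compound 3 (within the scatter), which would lie within the scatter.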

Compound 3, a percentage reported as activity, at one concentration (the size of the read-out at that concentration, not a potency): 71.5%
The estimate for compound 3 lay 3.5 percentage points below the measured number; the range from low to high includes it.
By their numbers in this assay, from the lowest: compounds 1, 2 and 3 (each within the scatter of the next).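

In this assay, 3-(trifluoromethyl)phenyl in place of 4-(trifluoromethyl)phenyl on the aromatic nitrogen gives a number 0.8 percentage points higher from compound 2 to compound 3 (within the scatter), so at the one concentration tested this read-out does not separate the two placements of the trifluoromethyl group on that phenyl ring. With 3-(trifluoromethyl)phenyl in place of 4-ethylphenyl at the same nitrogen, the step is a number 7.1 percentage points higher from compound 1 to compound 3 (within the scatter), which means that all three groups tried at this position now lie within the scatter of one another, and neither the change of group nor the change of placement has yet moved the number measurably. No accompanying measurement bears on this result.

The compounds shown carry only ethyl or trifluoromethyl on this phenyl ring, so the effect of an amine or a carboxylic acid there in this assay remains open. From the compounds shown here alone, the 2-hydroxyphenyl and 2-hydroxy-4-(trifluoromethyl)phenyl groups are the same in all three compounds, so what each contributes to the read-out also remains open, as does whether these compounds would separate at any other concentration.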